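A few compounds are considered here, and "the series" means these few. Any claim that something is new, unique, unknown or untested is made for them only; others in the source may bear on it.

Compound 1 `C#Cc1cn([C@@H]2O[C@H](CO)[C@@H](O)[C@H]2O)c2ncnc(OC)c12` carries an ethynyl group and a methoxy group on its core, together with a sugar. Among the measured compounds shown here, in a functional assay on HCT-116 cells (Homo sapiens), read by MTT assay, with a stated time of 72 h (a higher number here means a weaker inhibitor, a lower number a stronger inhibitor), compound 1 gives 5140 nM, the highest of the two numbers measured so far; its nearest neighbour is compound 2 `COc1ncnc2c1c(-c1ccco1)cn2[C@@H]1O[C@H](CO)[C@@H](O)[C@H]1O`, which in this assay gives 40 nM. For the measured compounds named here, the one measured step, a 130-fold lower number from compound 1 to compound 2 (2.11 log units; beyond the scatter), came from a furan-2-yl in place of ethynyl on an aromatic carbon, and it is large.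

Compound 3 `C#Cc1cn([C@@H]2O[C@H](CO)[C@@H](O)[C@H]2O)c2nc(N)nc(OC)c12` is not yet measured. It differs from compound 1 by amino in place of hydrogen on an aromatic carbon. Going by the values given here, this is a change at a different place from the one measured step, which swapped the ethynyl group and left the six-membered ring untouched, so that step offers no guide here, and nothing measured speaks to adding an amino group at this position. With no evidence for a shift, compound 3 is expected to give about 5000 nM in this assay, with a range from 1500 nM to 16000 nM. The expected step is a 1.0-fold lower number from compound 1 to compound 3 (0.01 log units; within the scatter), no larger than the usual scatter.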

Compound 3, half-maximal inhibitory concentration: > 20000 nM
Compound 3 was reported as a limit; the forecaster's own chance of this, stated with the estimate: 5%; middle value at least 4.0-fold (0.60 log units) from the limit.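

Among the compounds shown here, the position on the six-membered aromatic ring between two ring nitrogen atoms was untouched in compound 1 and compound 2, so compound 3 is the first look at it, and the position proves sensitive to change. In this assay compound 3 gives > 20000 nM, which is a limit of the assay and not a number. Even so, the direction can be read: amino in place of hydrogen at this position gives an at least 3.8-fold higher number from compound 1 to compound 3 (0.59 log units; beyond the scatter), so one added nitrogen moves an already weak compound further towards weakness, while the earlier change at the ethynyl group moved the number the other way.

On these data alone, how far compound 3 lies past that limit, and so the true size of this step, stays unknown: the limit of > 20000 nM in this assay, at which 1 of the 3 values shown sits. Also open, as far as these compounds go, is whether a different group at this position, such as methyl, a chlorine atom or dimethylamino, would raise the number in the same way, and whether amino would do the same on the furan-2-yl compound 2, where the starting number is far lower.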